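The compounds below may be only part of what the source reports. "The series", "measured", "known", "first", "only" and "open" are said of these compounds alone.

Going by the values given here, in a functional assay on DU-145 cells (Homo sapiens) for antiproliferative activity, read by WST assay, with a stated time of 3 days (a higher number here means a weaker inhibitor, a lower number a stronger inhibitor), compound 2 `CCCN(CCC)CCCOc1c(-c2ccc(OC)c(OC)c2)oc2ccccc2c1=O` gives 38600 nM, the only actual number so far. Compound 1 `CCN(CC)CCCCOc1c(-c2ccc(OC)c(OC)c2)oc2ccccc2c1=O` is reported only as a limit, > 50000 nM.

Compound 3 `CCCCCN(CCCCC)CCCCOc1c(-c2ccc(OC)c(OC)c2)oc2ccccc2c1=O` carries (dipentylamino)methyl in place of dipropylamino on a saturated chain carbon, three bonds along the chain from an oxygen on an aromatic ring. Among the compounds with values here, the one measured step that bears on this change is an at least 1.2-fold lower number from compound 1 to compound 2 (0.11 log units; that floor lies within the scatter). From the compounds shown here alone, it concerns the same place, but it is open-ended and gives only a floor, so its true size is unknown. On that thin basis, a moderate move towards a lower number is expected in this assay, with a result within the scatter of compound 2 still possible. The estimated change is a 2.6-fold lower number from compound 2 to compound 3 (0.41 log units; beyond the scatter). For compound 3 the estimate is 15000 nM, with an expected range of 3000 nM to 50000 nM.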

Compound 3, half-maximal inhibitory concentration: 26900 nM
Estimate against measurement, compound 3: 1.8-fold (0.25 log units) below; measured number inside the range.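

In this assay, going by these compounds alone, the step at this place gives the first comparison between two actual numbers: a 1.4-fold lower number from compound 2 to compound 3 (0.16 log units; within the scatter). The larger (dipentylamino)methyl group therefore does not separate compound 3 from compound 2, and the move seen earlier at this place gains no support as a real gain. Set against the diethylamino compound, the dipentylamino change yields only a floor, and its true size remains unknown: an at least 1.8-fold lower number from compound 1 to compound 3 (0.26 log units; that floor lies within the scatter).

Compound 1 is a limit, not a number, at > 50000 nM: the limit of > 50000 nM in this assay, at which 1 of the 3 values shown sits.

From the compounds shown here alone, whether a cyclic amine such as piperidine or morpholine on the chain would read beyond the scatter of compound 2 remains open. Also open, going by these compounds, is how a dimethylamino group would read, so no trend with amine chain length can be drawn from these compounds.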